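A few compounds are considered here, and "the series" means these few. Any claim that something is new, unique, unknown or untested is made for them only; others in the source may bear on it.

Measured so far in this set:
compound 1 `C[C@H](Oc1ccc(S(C)(=O)=O)cc1C(=O)N1Cc2ccc(N3CCCC3)cc2C1)C(F)(F)F` with 180 nM
compound 2 `C[C@H](Oc1ccc(S(C)(=O)=O)cc1C(=O)N1Cc2cccc(C#N)c2C1)C(F)(F)F` with 770 nM
compound 3 `C[C@H](Oc1ccc(S(C)(=O)=O)cc1C(=O)N1Cc2cnc(C(F)(F)F)cc2C1)C(F)(F)F` with 132 nM

All three were tested in an assay on CHO cells for inhibition of sodium- and chloride-dependent glycine transporter 1 (Homo sapiens), read by scintillation counting; on this read-out higher numbers stand for an effect only at larger amounts of compound and lower numbers for an effect already at smaller amounts. Compound 1 gives the second highest of the three numbers. Its nearest neighbour is compound 3, whose value of 132 nM lies within the scatter of compound 1. The furthest is compound 2, whose value of 770 nM stands beyond the scatter, a clearly higher number than compound 1.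

Compound 4 `C[C@H](Oc1ccc(S(C)(=O)=O)cc1C(=O)N1Cc2ccc(C3CCOCC3)cc2C1)C(F)(F)F` has not yet been measured. It differs from compound 1 by oxan-4-yl in place of pyrrolidin-1-yl on an aromatic carbon. Among the measured compounds shown here, no measured pair shows this change, so the direction is open. Compound 4 is expected to give about 300 nM, within a range from 100 nM to 900 nM. The expected step from compound 1 to compound 4 is a 1.7-fold higher number from compound 1 to compound 4 (0.22 log units; within the scatter), a shift that may well stay within the scatter.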

Compound 4, half-maximal effective concentration: 14 nM
Estimate against measurement, compound 4: 21-fold (1.33 log units) above; the measured number lies below the stated range.
By their numbers in this assay, from the lowest: compound 4; then compounds 3 and 1 (each within the scatter of the next); then compound 2.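

In this assay, this place on the aromatic ring proves sensitive to the group it carries: oxan-4-yl in place of pyrrolidin-1-yl gives a 13-fold lower number from compound 1 to compound 4 (1.11 log units; beyond the scatter). Both groups are non-aromatic rings with no net charge, yet the step is large and lies beyond the scatter. Nothing available here explains its size.

The compounds shown do not separate the effects of ring size, the ring oxygen, and attachment through carbon rather than nitrogen. On these data alone, how a cyclohexyl or morpholin-4-yl group would compare at this place remains open.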